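Pyridyl for phenyl on the amine side of a boronic acid

This account rests on a few compounds, and the source may have more. Where it says the series, first, only, none or still open, it means among the compounds named here.

Compound 1, `CC(C)CN(NC(=O)OCc1ccccc1)C(=O)CN(Cc1ccccc1)/N=C/c1cccc(B(O)O)c1`: in a functional assay on B16 cells (Mus musculus) for inhibition (a lower number here means a stronger inhibitor, a higher number a weaker inhibitor), compound 1 gives 18400 nM.
Compound 2, `CC(C)CN(CC(=O)N(Cc1ccccc1)NC(=O)OCc1ccccc1)/N=C/c1cccc(B(O)O)c1`: in this assay compound 2 gives 19900 nM.
Compound 3, `CC(C)CN(CC(=O)N(Cc1cccnc1)NC(=O)OCc1ccccc1)/N=C/c1cccc(B(O)O)c1`: in this assay compound 3 gives 40300 nM.

Compound 1 and compound 2 have the same atoms joined differently; the difference between the two cores is not broken down here, and their two values lie within the scatter of each other. Compound 3 carries pyridin-3-yl in place of phenyl on a saturated chain carbon bound to an amide-type nitrogen. That step measured a 2.0-fold higher number from compound 2 to compound 3 (0.31 log units; beyond the scatter). Compound 4, `CC(C)CN(NC(=O)OCc1ccccc1)C(=O)CN(Cc1cccnc1)/N=C/c1cccc(B(O)O)c1`, is not yet measured; it carries pyridin-3-yl in place of phenyl on a saturated chain carbon bound to an amine nitrogen. This is the same kind of change, not the same: there the saturated chain carbon is bound to an amide-type nitrogen, here to an amine nitrogen. Among the compounds with values here, the expectation rests on the single measured instance, a 2.0-fold higher number from compound 2 to compound 3 (0.31 log units; beyond the scatter). For compound 1 the expected step is a 2.0-fold higher number from compound 1 to compound 4 (0.30 log units; within the scatter). Compound 4 is therefore estimated at 37000 nM, between 20000 nM and 70000 nM.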

Compound 4, half-maximal inhibitory concentration: 60900 nM
Estimate against measurement, compound 4: 1.6-fold (0.22 log units) below; measured number inside the range.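

On the core of compound 1, going from benzyl to (pyridin-3-yl)methyl gave a weaker inhibitor in this assay (a 3.3-fold higher number from compound 1 to compound 4 (0.52 log units; beyond the scatter)). The change moved the number the same way on both cores, and the two step sizes cannot be told apart: the same change on two cores in this assay, a 2.0-fold higher number (0.31 log units; beyond the scatter) from compound 2 to compound 3 and a 3.3-fold higher number (0.52 log units; beyond the scatter) from compound 1 to compound 4, 1.6-fold (0.21 log units) apart, within the scatter of two such steps. This shows that the change carried over between these two cores, but two pairs do not show that it would hold on other cores in the series, and they do not explain the loss.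

The compounds shown leave open how a cyclohexyl group or a longer chain such as phenethyl would behave in place of the phenyl. They also leave open whether the same change elsewhere on these cores would behave alike.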